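Series notes: methoxy in place of methyl

The compounds below may be only part of what the source reports. "The series", "measured", "known", "first", "only" and "open" are said of these compounds alone.

Going by the values given here, compound 1 `Cc1ccccc1NC(=S)N/N=C/c1ccc2ccccc2n1` is one of two compounds measured in a functional assay on HeLa cells (Homo sapiens) for antiproliferative activity, read by sulforhodamine B assay, with a stated time of 72 h; on this read-out higher numbers stand for weaker inhibition and lower numbers for stronger inhibition. In this assay compound 1 gives only a limit, > 100000 nM, and no number. Compound 2 `CN(C)C(=S)N/N=C/c1ccc2ccccc2n1` gives 90 nM in this assay. Of the two values shown, compound 1 sits at the limit of > 100000 nM in this assay, at which 1 of the 2 values shown sits, so where it stands is known only as that limit, while compound 2 stands well inside the measured range. Compound 3 `COc1ccccc1NC(=S)N/N=C/c1ccc2ccccc2n1` has not been measured. It differs from compound 1 by methoxy in place of methyl on an aromatic carbon. No step between measured compounds of a single difference is available, so the size of this change is not anchored by the numbers shown. The step of a number no higher from compound 1 to compound 3 (the limit leaves the size open) is expected to be none beyond the scatter, with the read-out most likely again a limit. Compound 3 is estimated at 100000 nM, within a range from 20000 nM to 300000 nM.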

Compound 3, half-maximal inhibitory concentration: > 100000 nM
Compound 3: a limit, no number; the forecaster's own chance of this, stated with the estimate: 70%; the middle value lies on the limit itself.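

Compound 1 and compound 3 both give only a limit in this assay, so no step can be read between them. The compounds shown leave open whether methoxy in place of methyl on an aromatic carbon changes the read-out at all.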